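Methoxyamino for methoxy on a 2'-methyl nucleoside core

This account rests on a few compounds, and the source may have more. Where it says the series, first, only, none or still open, it means among the compounds named here.

Measured compounds:
compound 1, `COc1nc(OC)c2ncn([C@@H]3O[C@H](CO)[C@@H](O)[C@@]3(C)O)c2n1`: > 100000 nM in an ADME assay on CCRF-CEM cells (Homo sapiens) for cytotoxicity, read by trypan blue exclusion, with a stated time of 6 days; on this read-out higher numbers stand for lower toxicity in this test and lower numbers for higher toxicity in this test
compound 2, `C[C@@]1(O)[C@H](O)[C@@H](CO)O[C@H]1n1cnc2c(N)nc(O)nc21`: > 100000 nM in this assay
compound 3, `COc1nc(N)c2ncn([C@@H]3O[C@H](CO)[C@@H](O)[C@@]3(C)O)c2n1`: > 100000 nM in this assay

Each of these three values is a limit of this assay, not a number. Compound 3 therefore has only a limit, and the two other compounds shown stand at the same limit, which is what the limit of > 100000 nM in this assay, at which 3 of the 3 values shown sit, records. The two measured steps that end at compound 3 cannot be read for size: a step that the two limits leave unreadable from compound 1 to compound 3 and a step that the two limits leave unreadable from compound 2 to compound 3 both run between limits, so neither an increase nor a decrease in toxicity can be taken from them.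

The next compound, compound 4, `CONc1nc(N)c2ncn([C@@H]3O[C@H](CO)[C@@H](O)[C@@]3(C)O)c2n1`, differs from compound 3 in one place: methoxyamino in place of methoxy on an aromatic carbon. Within the data shown here, no measured step in this assay bears on this change, and the two steps that reach compound 3 give no size at all. With every value in the series sitting at the limit, the working expectation is that compound 4 stays there as well, so that the step from compound 3 to compound 4 is expected to be a step that the limit leaves unreadable from compound 3 to compound 4, which is none beyond the scatter. Compound 4 is thus estimated at 150000 nM, with a range from 50000 nM to 500000 nM.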

Compound 4, half-maximal cytotoxic concentration: > 100000 nM
Compound 4 ended at the assay's limit (the forecaster's own chance of this, stated with the estimate: 85%); the middle value is on the limit's open side.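

Compound 4 adds no readable step: the changes from compound 3 and from compound 2 to compound 4 both run between limits, so neither can be sized, and the whole series stands at one limit: the limit of > 100000 nM in this assay, at which 4 of the 4 values shown sit. The compounds shown leave open whether methoxyamino, methoxy or hydroxy on that aromatic carbon makes any difference to toxicity in this assay.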